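The source may report more compounds than this note shows. Statements on the series, on what has been measured and on what is new or still open speak of the compounds shown alone.

Compound 3 `Cc1cc(Cl)ccc1C(=O)Nc1ccc(Cl)c(-c2nnc3c(Cl)cccn23)c1` stands at the assay limit in a functional assay on MDA-MB-231 cells (Homo sapiens) for antiproliferative activity, read by MTT assay, with stated times of 72 h and 4 h (on this read-out lower numbers stand for stronger inhibition and higher numbers for weaker inhibition), giving > 100000 nM. Compound 1 `Cc1nc(C(=O)Nc2ccc(Cl)c(-c3nnc4c(Cl)cccn34)c2)cs1` is likewise only a limit, at > 100000 nM. Compound 2 `O=C(Nc1ccc(Cl)c(-c2nnc3c(Cl)cccn23)c1)c1c(F)cccc1Cl` is also a limit, at > 100000 nM. All three values sit on (the limit of > 100000 nM in this assay, at which 3 of the 3 values shown sit), so the changes on the carbonyl carbon, a step that the two limits leave unreadable from compound 1 to compound 2, a step that the two limits leave unreadable from compound 1 to compound 3 and a step that the two limits leave unreadable from compound 2 to compound 3, cannot be sized. Compound 4 `O=C(Nc1ccc(Cl)c(-c2nnc3c(Cl)cccn23)c1)c1ccon1` differs from compound 3 by 1,2-oxazol-3-yl in place of 4-chloro-2-methylphenyl on a carbonyl carbon. Among the measured compounds shown here, no measured step bears on this change beyond the observation that three different groups on the carbonyl carbon all leave the series at the limit. The expected step is a number no higher from compound 3 to compound 4 (the limit leaves the size open), not readable against a limit. Compound 4 is expected to give about 100000 nM, between 30000 nM and 300000 nM, most likely again reported only as a limit.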

Compound 4, half-maximal inhibitory concentration: > 100000 nM
Compound 4: no number, only a limit (the forecaster's own chance of this, stated with the estimate: 85%); the middle value lies on the limit itself.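

Compound 4 gives > 100000 nM, which is only a limit. No step from compound 1, compound 2 or compound 3 to compound 4 can be read: the limit of > 100000 nM in this assay, at which 4 of the 4 values shown sit.

The compounds shown leave open whether any group on the carbonyl carbon of the shared core gives a measurable value.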